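The source may hold more compounds than are shown below. What is called first, only, known or untested is meant among the compounds shown, and "the series" means these compounds.

Measured so far in an in vitro ADME assay on microsomes from liver (Homo sapiens) for metabolic stability, read by LC-MS, tested at 1 uM; on this read-out lower numbers stand for a shorter-lived compound and higher numbers for a longer-lived compound:
compound 1 `CC(C)n1ccnc1/N=C(/Nc1ccc(Cl)c(Cl)c1)NC(C)(C)C` gives 0.673 h
compound 2 `CCC(CC)C(=O)N/C(=N/c1nccn1C(C)C)Nc1ccc(Cl)c(Cl)c1` gives > 1 h

Compound 1 is the one of the two that returns a plain number. Compound 2 returns only > 1 h, which is a limit of this assay and not a number; where it stands is known only as a range (the limit of > 1 h in this assay, at which 1 of the 2 values shown sits). Among the compounds with values here, no step between measured compounds that differ in one place is available, so nothing in the pair tells how a change at the carbonyl carbon shifts the half-life.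

Compound 3 `CC(C)n1ccnc1/N=C(/NC(=O)OC(C)(C)C)Nc1ccc(Cl)c(Cl)c1` is not yet measured. It differs from compound 2 in one place: tert-butoxy in place of pentan-3-yl on a carbonyl carbon whose other neighbour is an amide-type nitrogen; read one bond further out, a (pentan-3-yl)carbonyl becomes a tert-butoxycarbonyl. With nothing measured for this kind of change, the expected step that the limit leaves unreadable from compound 2 to compound 3 is set at no shift beyond the usual scatter. Compound 3 is therefore estimated at 1.2 h, with a range from 0.5 h to 3 h, and a fair chance that this assay again returns only its limit.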

Compound 3, half-life: > 1 h
Compound 3: only a limit was reported; the forecaster's own chance of this, stated with the estimate: 55%; the middle value is on the limit's open side.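

In this assay, compound 2 and compound 3 both return only a limit and not a number, so no step between them can be read: the limit of > 1 h in this assay, at which 2 of the 3 values shown sit.

Still open, from the compounds shown here alone, is how far the half-lives of compound 2 and compound 3 lie past that limit, and whether tert-butoxy in place of pentan-3-yl on a carbonyl carbon shifts the half-life at all.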